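From methyl to pyrrolidinyl on the aromatic carbon

The compounds below may be only part of what the source reports. "The series", "measured", "known", "first", "only" and "open" are said of these compounds alone.

Compound 1 `Cc1ccccc1-c1cnc(Nc2cccc3c2CC(O)CC3)o1`: 416 nM
Compound 2 `Cc1cccc(-c2cnc(Nc3cccc4c3CC(O)CC4)o2)c1`: 157 nM
Compound 3 `Cc1ccc(-c2cnc(Nc3cccc4c3CC(O)CC4)o2)cc1`: 62 nM

The three compounds share one core and differ only in where the methyl sits on the six-membered aromatic ring of carbon only. In an in vitro functional assay on cells for antagonist activity at transient receptor potential cation channel subfamily V member 1 (Homo sapiens), read by FLIPR and calcium flux (a higher number here means a weaker inhibitor, a lower number a stronger inhibitor), compound 3 gives the lowest number of the three: a 2.5-fold lower number from compound 2 to compound 3 (0.40 log units; beyond the scatter) and a 6.7-fold lower number from compound 1 to compound 3 (0.83 log units; beyond the scatter), while a 2.6-fold lower number from compound 1 to compound 2 (0.42 log units; beyond the scatter) separates the other two. Compound 4 `OC1CCc2cccc(Nc3ncc(-c4ccc(N5CCCC5)cc4)o3)c2C1` carries the change (pyrrolidin-1-yl in place of methyl on an aromatic carbon). For the measured compounds named here, none of the measured steps bears directly on this exchange; each of them moves the methyl rather than replacing it, so they offer no size for the step. The step is therefore expected to be small, a 1.4-fold lower number from compound 3 to compound 4 (0.14 log units; within the scatter). Compound 4 is estimated at 45 nM, between 12 nM and 180 nM.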

Compound 4, half-maximal inhibitory concentration: 101 nM
Beside the measured number, compound 4's estimate is 2.2-fold (0.35 log units) below it; low and high end bracket the measured number.
By their numbers in this assay, from the lowest: compounds 3, 4 and 2 (each within the scatter of the next, the first and the last beyond it); then compound 1.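

Swapping methyl for pyrrolidin-1-yl on the aromatic carbon para to a large group adds a ring and a hydrogen-bond acceptor, yet in this assay the result is a 1.6-fold higher number from compound 3 to compound 4 (0.21 log units; within the scatter). The earlier compounds shown here only moved a methyl around the ring, whereas this pair shows that the position accepts a much larger group with no change beyond the scatter. No supporting data offer an account of this result.

Going by these compounds, it remains open whether a carboxylic acid or a longer alkyl chain would fare alike at this position. Equally open, on these data alone, is whether pyrrolidin-1-yl would track the methyl series at the other ring positions.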